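The compounds below may be only part of what the source reports. "The series", "measured", "known", "first", "only" and "open" are said of these compounds alone.

Measured so far in a functional assay on EC9706 cells (Homo sapiens) for cytotoxicity, read by MTT assay, with a stated time of 72 h; a lower number here means a stronger inhibitor, a higher number a weaker inhibitor:
Compound 1, `CCN(C)C(=O)N1CCN(C(=S)SCc2cn(Cc3ccccc3F)nn2)CC1`: 15600 nM.
Compound 2, `CCNC(=O)N1CCN(C(=S)SCc2cn(Cc3ccc(OC)cc3)nn2)CC1`: a limit only, > 128000 nM.
Compound 3, `COc1ccc(Cn2cc(CSC(=S)N3CCN(C(=O)NC(C)C)CC3)nn2)cc1`: a limit only, > 128000 nM.

Compound 3 stands at the assay limit, with no number behind it; compound 2 sits at the same limit (the limit of > 128000 nM in this assay, at which 2 of the 3 values shown sit). The step that the two limits leave unreadable from compound 2 to compound 3 therefore cannot be read. Compound 4, `CCN(C)C(=O)N1CCN(C(=S)SCc2cn(Cc3ccc(OC)cc3)nn2)CC1`, differs from compound 3 by ethyl(methyl)amino in place of isopropylamino on a carbonyl carbon. Among the compounds with values here, no measured step covers this change. Compound 1 carries the same ethyl(methyl)carbamoyl group and gives a number in this assay, 15600 nM, but its benzyl group differs as well, so the comparison is not clean. For compound 4 a weak value is expected, 60000 nM, within 15000 nM to 200000 nM, an estimated step of an at least 2.1-fold lower number from compound 3 to compound 4 (0.32 log units; beyond the scatter) that may again end at the limit.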

Compound 4, half-maximal inhibitory concentration: > 128000 nM
Compound 4: only a limit was reported; the forecaster's own chance of this, stated with the estimate: 45%; middle value at least 2.1-fold (0.32 log units) away from the limit.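

In this assay, compound 4 also gives only a limit, so ethyl(methyl)carbamoyl in place of isopropylcarbamoyl yields no number, and the steps among compound 2, compound 3 and compound 4 cannot be read. Within the data shown here, the one readable step, an at least 8.2-fold higher number from compound 1 to compound 4 (0.91 log units; beyond the scatter), is 4-methoxyphenyl in place of 2-fluorophenyl on a saturated chain carbon bound to an aromatic nitrogen, which places the only measured difference at that group. The carbamoyl position stays unresolved with 4-methoxyphenyl in place: the limit of > 128000 nM in this assay, at which 3 of the 4 values shown sit.

Still open, going by these compounds, is how isopropylcarbamoyl reads with 2-fluorophenyl. Also open, on these data alone, is whether a carboxylic acid or an amine in place of 4-methoxyphenyl would give a number.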